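Dropping the chloro from compound 1: what to expect

The compounds below may be only part of what the source reports. "The series", "measured", "known", "first", "only" and "open" are said of these compounds alone.

Compounds measured so far:
compound 1 `N#Cc1ccc(NC(=O)c2ccc3cccnc3c2O)c(Cl)c1` — 3670 nM
compound 2 `N#Cc1ccc(NC(=O)c2cc(Cl)ccc2O)c(Cl)c1` — 860 nM

In a functional assay on KG-1 cells (Homo sapiens) for cytotoxicity, read by luminescence and CellTiter-Glo, with a stated time of 3 days (a lower number here means a stronger inhibitor, a higher number a weaker inhibitor), compound 1 gives 3670 nM, the higher of the two numbers available, so among the measured pair it is the weaker inhibitor. Compound 2, built on a different core, gives 860 nM in this assay, and the gap between these two values lies beyond the usual scatter; as the two compounds differ in more than one place, nothing more is drawn from that comparison.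

Compound 3 `N#Cc1ccc(NC(=O)c2ccc3cccnc3c2O)cc1` shares the core of compound 1 and differs from it in a single change: hydrogen in place of chloro on an aromatic carbon. Going by the values given here, no measured pair shows the effect of this exact change on this assay, so the expected direction rests on the structural change alone. Losing the chloro, which sits ortho to a large group and meta to a cyano group, is expected to give a modest move toward a higher number, a step of a 1.9-fold higher number from compound 1 to compound 3 (0.28 log units; within the scatter), perhaps only a little beyond the scatter.

Compound 3 is therefore estimated at 7000 nM in this assay, with a range from 2500 nM to 20000 nM.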

Compound 3, half-maximal inhibitory concentration: 2320 nM
Beside the measured number, compound 3's estimate is 3.0-fold (0.48 log units) above it; measured number outside the range, below it.
By their numbers in this assay, from the lowest: compound 2; then compounds 3 and 1 (each within the scatter of the next).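

In this assay, hydrogen in place of chloro on the aromatic carbon ortho to a large group and meta to a cyano group gives a 1.6-fold lower number from compound 1 to compound 3 (0.20 log units; within the scatter). Going by these compounds alone, this is the first comparison that isolates a single place, and it shows that, on this core and in this assay, compound 1 and compound 3 cannot be told apart, so the chloro is not needed for the level of cytotoxicity seen with compound 1. Nothing available gives a reason for this result, and none is offered here.

On these data alone, this single step speaks for one position on one core, so it is unknown whether the same exchange on the core of compound 2 would also leave the number within the scatter. As far as these compounds go, it also remains open whether a fluoro, a methyl, a methoxy or an amine on this same aromatic carbon would separate from hydrogen and chloro, or whether this position would accept any of them with as little effect on the number.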